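A few compounds are considered here, and "the series" means these few. Any claim that something is new, unique, unknown or untested is made for them only; others in the source may bear on it.

Three compounds were measured in a functional assay on NCI-H460 cells (Homo sapiens) for antiproliferative activity, read by CCK-8 assay, with a stated time of 72 h, tested at 8 uM; on this read-out lower numbers stand for a weaker effect and higher numbers for a stronger effect at the one concentration tested. Compound 1 `CC1CCN(c2nc(Cl)nc3c2ncn3Cc2ccc(/C=C/C(=O)Nc3ccccc3N)cc2)CC1` gives 10.8%. Compound 2 `Nc1ccccc1NC(=O)/C=C/c1ccc(Cn2cnc3c(Nc4cccc(OC(F)(F)F)c4)nc(Cl)nc32)cc1` gives 66.7%. Compound 3 `Nc1ccccc1NC(=O)c1ccc(Cn2cnc3c(Nc4cccc(OC(F)(F)F)c4)nc(Cl)nc32)cc1` gives 62.4%. The change 4-methylpiperidin-1-yl in place of (3-(trifluoromethoxy)phenyl)amino on an aromatic carbon produced a number 55.9 percentage points lower from compound 2 to compound 1 (beyond the scatter). The cores of compound 2 and compound 3 differ by (2-aminophenyl)carbamoyl in place of 2-((2-aminophenyl)carbamoyl)ethenyl on an aromatic carbon, and a number 4.3 percentage points lower from compound 2 to compound 3 (within the scatter).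

Compound 4 `CC1CCN(c2nc(Cl)nc3c2ncn3Cc2ccc(C(=O)Nc3ccccc3N)cc2)CC1` has not yet been measured. It differs from compound 3 by 4-methylpiperidin-1-yl in place of (3-(trifluoromethoxy)phenyl)amino on an aromatic carbon, the same change that was made from compound 2 to compound 1; among these four compounds it occurs twice. Because of a number 55.9 percentage points lower from compound 2 to compound 1 (beyond the scatter) the same kind of drop is expected here, with a number 54.4 percentage points lower from compound 3 to compound 4 (beyond the scatter) as the estimated step, starting from the value of compound 3, 62.4%. Compound 4 is therefore expected to give about 8% in this assay, estimated to lie between 0% and 22%.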

Compound 4, a percentage reported as inhibition, at one concentration (the size of the read-out at that concentration, not a potency): 40.9%
Estimate against measurement, compound 4: 32.9 percentage points below, outside the stated range (above it).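

The change to 4-methylpiperidin-1-yl gives a number 21.5 percentage points lower from compound 3 to compound 4 (beyond the scatter) in this assay, so the direction holds on both cores but the size does not carry over: the same change on two cores in this assay, a number 55.9 percentage points lower (beyond the scatter) from compound 2 to compound 1 and a number 21.5 percentage points lower (beyond the scatter) from compound 3 to compound 4, 34.4 percentage points apart, beyond the scatter of two such steps

The change to (2-aminophenyl)carbamoyl from 2-((2-aminophenyl)carbamoyl)ethenyl gives a number 30.1 percentage points higher from compound 1 to compound 4 (beyond the scatter), and this step does not carry from one core to the other either: the same change on two cores in this assay, a number 4.3 percentage points lower (within the scatter) from compound 2 to compound 3 and a number 30.1 percentage points higher (beyond the scatter) from compound 1 to compound 4, 34.4 percentage points apart, beyond the scatter of two such steps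

These four compounds show that the two changes do not act independently here, but they do not show why, and they rest on one concentration in one cell line.

From the compounds shown here alone, it remains open whether other groups on the same aromatic carbon, such as morpholin-4-yl or an unsubstituted piperidin-1-yl, would follow compound 1 and compound 4. A longer chain in place of the ethenyl link is also left open.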